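This account rests on a few compounds, and the source may have more. Where it says the series, first, only, none or still open, it means among the compounds named here.

Compound 1 `COc1ccc(C(=O)OC2(C(=O)Nc3ccc([N+](=O)[O-])cc3)CCCCC2)cc1` gives 38.8 nM in a functional assay on NFS-60 cells (Mus musculus) for inhibition, read by MTT assay, with a stated time of 72 h; a higher number here means a weaker inhibitor, a lower number a stronger inhibitor. Compound 2 `CCOC(=O)c1ccccc1C(=O)OC1(C(=O)Nc2ccc([N+](=O)[O-])cc2)CCCCC1` gives 488 nM in this assay. Compound 3 `O=C(OC1(C(=O)Nc2ccc([N+](=O)[O-])cc2)CCCCC1)c1ccccc1` gives 766 nM in this assay.

Compound 2 stands second highest of the three numbers, with compound 3 nearest and compound 1 furthest. Compound 4 `CC(=O)Oc1ccccc1C(=O)OC1(C(=O)Nc2ccc([N+](=O)[O-])cc2)CCCCC1` differs from compound 2 by acetoxy in place of ethoxycarbonyl on an aromatic carbon. The step that bears on this is a 1.6-fold higher number from compound 2 to compound 3 (0.20 log units; within the scatter), which shows that the group on this carbon barely moves the number; the step of a 20-fold higher number from compound 1 to compound 3 (1.30 log units; beyond the scatter) was large but concerns another position. A step of no more than the scatter is therefore expected, a 1.2-fold higher number from compound 2 to compound 4 (0.09 log units; within the scatter). Compound 4 is estimated at 600 nM, within 250 nM to 1500 nM.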

Compound 4, half-maximal inhibitory concentration: 11.3 nM
The estimate for compound 4 lay 53-fold (1.73 log units) above the measured number; measured number below the stated range.
By their numbers in this assay, from the lowest: compound 4; then compound 1; then compounds 2 and 3 (each within the scatter of the next).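

In this assay the group on this aromatic carbon, ortho to a large group, matters greatly after all: acetoxy in place of ethoxycarbonyl, with the same hydrogen-bond counts, gives a large drop (a 43-fold lower number from compound 2 to compound 4 (1.64 log units; beyond the scatter)), and acetoxy in place of hydrogen gives a larger one (a 68-fold lower number from compound 3 to compound 4 (1.83 log units; beyond the scatter)), so the earlier small step held for ethoxycarbonyl only. The 2-acetoxyphenyl group also beats the 4-methoxyphenyl group, though modestly (a 3.4-fold lower number from compound 1 to compound 4 (0.54 log units; beyond the scatter)). Nothing available here explains this gain.

Whether it depends on the acetoxy group itself stays open, since a hydroxyl group or a longer acyloxy chain on this carbon is not among the compounds shown. As far as these compounds go, how an amine there would behave is equally open.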